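The compounds below may be only part of what the source reports. "The series", "measured", "known", "first", "only" and "open" are said of these compounds alone.

Measured in a functional assay on B16 cells (Mus musculus) for inhibition; on this read-out higher numbers stand for weaker inhibition and lower numbers for stronger inhibition:
- compound 1, `COC(=O)Nc1nc2ccc(C(=O)c3cccs3)cc2n1C`, gives 40000 nM
- compound 2, `COC(=O)Nc1nc2cc(C(=O)c3sccc3C)ccc2[nH]1`, gives 2000 nM
- compound 3, `COC(=O)Nc1nc2cc(C(=O)c3cc(C)cs3)ccc2[nH]1`, gives 100 nM

Compound 3 stands at the lowest number of the three in this assay; its nearest neighbour is compound 2, its furthest compound 1, and both gaps lie beyond the scatter. Within the data shown here, compound 1 differs from compounds 2 and 3 in more than one place and carries no single step.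

Compound 4, `COC(=O)Nc1nc2cc(C(=O)c3ccc(C)s3)ccc2[nH]1`, is not yet measured. Compared with compound 3 the change is 5-methylthiophen-2-yl in place of 4-methylthiophen-2-yl on a carbonyl carbon.

Among the measured compounds shown here, no measured step carries the same change. For the measured compounds named here, the only step on the thiophene methyl is a 20-fold lower number from compound 2 to compound 3 (1.30 log units; beyond the scatter), which shows that where the methyl sits on the ring can shift the number strongly in this assay. It gives no direction for the present change, since the pair of compound 3 and compound 4 is a different pairing of positions. The expected step is therefore uncertain in sign; a move of the size seen before is possible, and a modest weakening is taken as the middle case.

For compound 4 the estimate in this assay is 300 nM, with a range from 60 nM to 2000 nM, which corresponds to an expected step of a 3.0-fold higher number from compound 3 to compound 4 (0.48 log units; beyond the scatter).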

Compound 4, half-maximal inhibitory concentration: 10000 nM
For compound 4 the middle estimate is 33-fold (1.52 log units) below the measured one; measured number above the stated range.
By their numbers in this assay, from the lowest: compound 3; then compound 2; then compound 4; then compound 1.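

In this assay, the single shift from 4-methylthiophen-2-yl to 5-methylthiophen-2-yl on the carbonyl carbon gives a 100-fold higher number from compound 3 to compound 4 (2.00 log units; beyond the scatter), so this methyl placement can cost far more than the earlier step on the ring suggested. The placement of the methyl now also separates the two weaker isomers, with a 5.0-fold higher number from compound 2 to compound 4 (0.70 log units; beyond the scatter), which gives a complete order for the three methylthiophen-2-yl isomers: the 4-methyl isomer has the lowest number, the 3-methyl isomer is next, and the 5-methyl isomer has the highest. The atoms are the same across compound 2, compound 3 and compound 4, and nothing available here bears on what lies behind this sensitivity to methyl placement.

Going by these compounds, it remains open whether the methyl in 4-methylthiophen-2-yl contributes to the number of compound 3 at all, since compound 1 carries an unsubstituted thiophen-2-yl but differs from compound 3 in more than one place. An unsubstituted thiophen-2-yl on the core of compound 3, or an ethyl, a chlorine or a methoxy group in place of that methyl, would show how much of the number depends on the methyl itself.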